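Extending chain unsaturation across two related pyranone cores

The compounds below may be only part of what the source reports. "The series", "measured", "known", "first", "only" and "open" are said of these compounds alone.

Of the compounds shown here, three have been tested in a functional assay on MCF7 cells (Homo sapiens) for antiproliferative activity, read by MTT assay; a higher number here means a weaker inhibitor, a lower number a stronger inhibitor. Compound 1, `CC/C=C\C/C=C\C/C=C\CCCCCCCc1cc(=O)c2c(O)cc(OCOC)c(C)c2o1`, gives 17500 nM. Compound 2, `CCCCC/C=C\C/C=C\CCCCCCCC1(O)CC(=O)c2c(O)c(C)c(O)c(C)c2O1`, gives 43200 nM, the highest of the two numbers. For compound 3, `CCCCC/C=C\C/C=C\CCCCCCCc1cc(=O)c2c(O)cc(OCOC)c(C)c2o1`, the result is a limit of the assay, > 84100 nM. Compound 3 and compound 1 differ by but-1-en-1-yl in place of butyl on a saturated chain carbon bound to a double-bonded chain carbon, and this change gave an at least 4.8-fold lower number from compound 3 to compound 1 (0.68 log units; beyond the scatter). How the core of compound 2 differs from the core of compound 3 is not broken down here. Compound 4, `CC/C=C\C/C=C\C/C=C\CCCCCCCC1(O)CC(=O)c2c(O)c(C)c(O)c(C)c2O1`, is not yet measured; it differs from compound 2 by but-1-en-1-yl in place of butyl on a saturated chain carbon bound to a double-bonded chain carbon, the same change in the same place. Resting on compound 3 and an at least 4.8-fold lower number from compound 3 to compound 1 (0.68 log units; beyond the scatter), a comparable step is expected, a 3.1-fold lower number from compound 2 to compound 4 (0.49 log units; beyond the scatter). Compound 4 is therefore estimated at 14000 nM, within 5000 nM and 40000 nM.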

Compound 4, half-maximal inhibitory concentration: 43200 nM
Estimate against measurement, compound 4: 3.1-fold (0.49 log units) below, outside the stated range (above it).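

The chain change brought no change at the digits printed from compound 2 to compound 4 (within the scatter) in this assay, so the step seen on the core of compound 1 did not carry over to the core of compound 4, and the two cores part clearly: the same change on two cores in this assay, an at least 4.8-fold lower number (0.68 log units; beyond the scatter) from compound 3 to compound 1 and no change at the digits printed (within the scatter) from compound 2 to compound 4, at least 4.8-fold (0.68 log units) apart, beyond the scatter of two such steps

This does not show why the two cores behave differently, nor how large the earlier step really is. Compound 3 is recorded only at a limit of the assay, not as a number: the limit of > 84100 nM in this assay, at which 1 of the 4 values shown sits.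

Among the compounds shown here, only two pairs bear on this change, so whether it would lower the number on any further core stays open. Also open, as far as these compounds go, is how compounds carrying a longer chain or a carboxylic acid would read in this assay.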